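A few compounds are considered here, and "the series" means these few. Any claim that something is new, unique, unknown or untested is made for them only; others in the source may bear on it.

Working notes on the series

Two compounds share the core and differ only in the halogen on the aryl sulfonyl ring. Compound 1, `CCN1CCC(n2cc(S(=O)(=O)c3cccc(F)c3)c3cccnc32)C1`, gives 8.3 nM in an assay on HeLa cells for displacement of a labelled ligand from 5-hydroxytryptamine receptor 6 (Homo sapiens); a higher number here means a weaker inhibitor, a lower number a stronger inhibitor. Compound 2, `CCN1CCC(n2cc(S(=O)(=O)c3cccc(Cl)c3)c3cccnc32)C1`, gives 3.3 nM in this assay. Among the compounds with values here, the one step measured so far, a 2.5-fold lower number from compound 1 to compound 2 (0.40 log units; beyond the scatter), is the only comparison available. On the two numbers shown, compound 2 stands at the lower of the two, with compound 1 as its nearest neighbour, higher by that same step.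

Compound 3, `O=S(=O)(c1cccc(Cl)c1)c1cn(C2CCCNC2)c2ncccc12`, carries the chloro aryl sulfonyl of compound 2 and changes the group on the aromatic nitrogen instead: piperidin-3-yl in place of 1-ethylpyrrolidin-3-yl on an aromatic nitrogen. Within the data shown here, no measured step touches this part of the molecule; the halogen step from compound 1 to compound 2 gives no guide to a change of the saturated amine ring or to the loss of the ethyl group. The expectation for compound 3 therefore rests on compound 2 alone, and the step from compound 2 to compound 3 is expected to be small, a 1.8-fold higher number from compound 2 to compound 3 (0.26 log units; within the scatter), with a wide range around it. For compound 3 in this assay a value of about 6 nM is estimated, expected to fall between 1.5 nM and 25 nM.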

Compound 3, inhibition constant: 1.3 nM
Compound 3: the middle estimate sits 4.6-fold (0.66 log units) above what was measured; measured number outside the range, below it.
By their numbers in this assay, from the lowest: compound 3; then compound 2; then compound 1.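

In this assay, the group on the aromatic nitrogen proves to be a place where the number can fall further, and the 1-ethylpyrrolidin-3-yl group is not needed to hold it low: the exchange for piperidin-3-yl gives a 2.5-fold lower number from compound 2 to compound 3 (0.40 log units; beyond the scatter). This single exchange bundles several differences, as the five-membered ring becomes a six-membered ring, the ethyl group is lost and a hydrogen-bond donor enters, so the step belongs to the exchange as a whole and to none of these parts alone. No measurement shown bears on what lies behind the step.

The compounds shown leave open which part of the exchange carries the step; a pyrrolidin-3-yl group without the ethyl chain and a 1-ethylpiperidin-3-yl group would divide it between ring size and the ethyl group. Also open, from the compounds shown here alone, is whether the chloro-for-fluoro step on the aryl sulfonyl ring holds with piperidin-3-yl on the aromatic nitrogen, and whether an open-chain aminoalkyl group could stand in place of the saturated ring.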